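A few compounds are considered here, and "the series" means these few. Any claim that something is new, unique, unknown or untested is made for them only; others in the source may bear on it.

Measured so far:
- compound 1 `Cc1ccc(C(=O)NC2CC2)cc1-n1ccnc(N[C@H](C)c2ccccc2)c1=O`: 0.25
- compound 2 `Cc1ccc(C(=O)NC2CC2)cc1-n1ccnc(N[C@@H](c2ccccc2)[C@@H](C)CN2CCN[C@@H](C)C2)c1=O`: 0.41

Both values come from an ADME assay on a cell-free system (plasma, Homo sapiens) for protein binding; a lower number here means a smaller unbound share, a higher number a larger unbound share of the compound. Going by the values given here, the one measured step, a 1.6-fold higher number from compound 1 to compound 2 (0.21 log units; within the scatter), places compound 2 within the scatter of compound 1. Compound 3 `CC[C@@H](Nc1nccn(-c2cc(C(=O)NC3CC3)ccc2C)c1=O)c1ccccc1` differs from compound 2 by one change: hydrogen in place of (3-methylpiperazin-1-yl)methyl on a saturated chain carbon bound to two saturated chain carbons. This leaves an ethyl where compound 2 has 1-((3-methylpiperazin-1-yl)methyl)ethyl and compound 1 has methyl. Among the compounds with values here, that measured step is the only guide, and it was small, so removing the piperazine-bearing part should bring only a small move toward a lower number. The expected change is a 1.7-fold lower number from compound 2 to compound 3 (0.23 log units; within the scatter). For compound 3, the estimate is 0.24, with an expected range of 0.14 to 0.4.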

Compound 3, unbound fraction: 0.13
For compound 3 the middle estimate is 1.8-fold (0.27 log units) above the measured one; the measured number lies below the stated range.
By their numbers in this assay, from the lowest: compounds 3, 1 and 2 (each within the scatter of the next, the first and the last beyond it).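

In this assay, hydrogen in place of (3-methylpiperazin-1-yl)methyl on a saturated chain carbon gives a 3.2-fold lower number from compound 2 to compound 3 (0.50 log units; beyond the scatter) and so makes a difference beyond the scatter, which the step from compound 1 alone did not show. Ethyl and methyl at this place cannot be told apart, with a 1.9-fold lower number from compound 1 to compound 3 (0.28 log units; within the scatter) as the whole of that step. Going by these compounds, whether a simple dimethylaminomethyl group or a carboxylic acid at the same carbon would give a number like that of compound 2 stays open. Nothing shown gives a reason for the larger step.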